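From compound 3 to the chloromethyl compound 4

The compounds below may be only part of what the source reports. "The series", "measured", "known", "first", "only" and "open" are said of these compounds alone.

In a functional assay on NCI-H460 cells (Homo sapiens) for cytotoxicity, read by MTT assay, with a stated time of 48 h (a lower number here means a stronger inhibitor, a higher number a weaker inhibitor), compound 3 `C=C1C(=O)O[C@H]2CC3=C[C@H](C/C(C)=C/[C@@H](OC(=O)/C=C/c4ccc(N(C)C)cc4)[C@H]12)OC3=O` gives 1300 nM as its value, and compound 2 `C=C1C(=O)O[C@H]2CC3=C[C@H](C/C(C)=C/[C@@H](OC(=O)c4ccc(C(C)=O)cc4)[C@H]12)OC3=O` gives 2200 nM as its value; the pair shows a 1.7-fold lower number from compound 2 to compound 3 (0.23 log units; within the scatter) and no more. Compound 1 `C=C1C(=O)O[C@H]2CC3=C[C@H](C/C(C)=C/[C@@H](OC(=O)c4ccc([N+](=O)[O-])cc4)[C@H]12)OC3=O` stands at > 10000 nM which is a limit and not a number. The steps from that limit are an at least 4.5-fold lower number from compound 1 to compound 2 (0.65 log units; beyond the scatter) and an at least 7.6-fold lower number from compound 1 to compound 3 (0.88 log units; beyond the scatter) in size. Compound 4 `C=C1C(=O)O[C@H]2CC3=C[C@H](C/C(C)=C/[C@@H](OC(=O)CCl)[C@H]12)OC3=O` brings chloromethyl in place of 2-(4-(dimethylamino)phenyl)ethenyl on a carbonyl carbon as its change: chloromethyl in place of 2-(4-(dimethylamino)phenyl)ethenyl on a carbonyl carbon. All three measured compounds keep an aromatic ring in that group, so the guidance is thin. Among the measured compounds shown here, with a 1.7-fold lower number from compound 2 to compound 3 (0.23 log units; within the scatter) as the nearest precedent, no shift beyond the scatter is expected. An estimated 1.5-fold higher number from compound 3 to compound 4 (0.19 log units; within the scatter) is expected in this assay with wide uncertainty. Compound 4 is estimated at 2000 nM within a range of 500 nM to 8000 nM for now.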

Compound 4, half-maximal inhibitory concentration: > 10000 nM
Compound 4: no number, only a limit; the forecaster's own chance of this, stated with the estimate: 15%; middle value at least 5.0-fold (0.69 log units) from the limit.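

In this assay, chloromethyl is the only group shown on this carbonyl carbon with no ring, and both readable steps are beyond the scatter: an at least 7.6-fold higher number from compound 3 to compound 4 (0.88 log units; beyond the scatter) and an at least 4.5-fold higher number from compound 2 to compound 4 (0.65 log units; beyond the scatter). A ring alone does not secure activity: compound 1 keeps one, yet it also ends at a limit, and the step between compound 1 and compound 4 cannot be read: the limit of > 10000 nM in this assay, at which 2 of the 4 values shown sit.

Still open, from the compounds shown here alone, is whether the loss follows the ring, the chlorine or the shorter group. A longer alkyl chain ending in a dimethylamino group, without a ring, would separate these.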